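This account rests on a few compounds, and the source may have more. Where it says the series, first, only, none or still open, it means among the compounds named here.

Of the compounds shown here, three built on one shared core have been tested in an ADME assay on MT4 cells (Homo sapiens) for cytotoxicity; a higher number here means that more compound is tolerated, a lower number that less compound is tolerated. Compound 1 `O=C(CSc1snnc1-c1ccccc1)Nc1ccccc1[N+](=O)[O-]` gives a reading of >= 246000 nM, which is a limit of the assay rather than a number. Compound 2 `O=C(CSc1snnc1-c1ccc(F)cc1F)Nc1ccccc1F` gives 148000 nM. Compound 3 `Cc1ccc(NC(=O)CSc2snnc2-c2ccccc2)c(Br)c1` gives > 297000 nM, again a limit of the assay and not a number. Compound 3 therefore stands at the edge of what the assay reports, as the limit of > 297000 nM in this assay, at which 1 of the 3 values shown sits, shows, and one further reading sits at a second limit, (the limit of >= 246000 nM in this assay, at which 1 of the 3 values shown sits), so only compound 2 carries a measured number.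

Compound 4 `O=C(CSc1snnc1-c1ccccc1)Nc1ccccc1F` has not yet been measured. It differs from compound 3 in one place: 2-fluorophenyl in place of 2-bromo-4-methylphenyl on an amide-type nitrogen. Among the measured compounds shown here, no step between two measured compounds covers this change, so its direction is open. Compound 2 also carries 2-fluorophenyl on the amide-type nitrogen and gives 148000 nM. On that basis the step of an at least 1.4-fold lower number from compound 3 to compound 4 (0.17 log units; that floor lies within the scatter) is expected to be small, probably within the scatter. Compound 4 is expected to give 200000 nM, with a range from 100000 nM to 400000 nM.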

Compound 4, half-maximal cytotoxic concentration: > 361000 nM
Compound 4 ended at the assay's limit; the forecaster's own chance of this, stated with the estimate: 50%; middle value at least 1.8-fold (0.25 log units) away from the limit.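

In this assay, with 2-fluorophenyl held fixed on the amide-type nitrogen, putting phenyl in place of 2,4-difluorophenyl on an aromatic carbon gives an at least 2.4-fold higher number from compound 2 to compound 4 (0.38 log units; beyond the scatter). Among the compounds shown here, this is the first readable step, and it shows that the group on that aromatic carbon can change how much compound is tolerated. Compound 4 reads > 361000 nM, which is a limit of the assay and not a number, so 2-fluorophenyl on the amide-type nitrogen does not by itself bring the reading down to a measured value.

The steps to compound 4 from compound 3 and from compound 1 cannot be read, so the groups on the amide-type nitrogen remain unranked. Also open, from the compounds shown here alone, is how this assay would respond to a carboxylic acid or an amine on the phenyl ring at that nitrogen.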